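Metabolic stability: moving from the hydroxamate to a carbon-linked amide

This account rests on a few compounds, and the source may have more. Where it says the series, first, only, none or still open, it means among the compounds named here.

Compound 1 `CC(C)CCn1nc(-c2cccs2)c(O)c(C2=NS(=O)(=O)c3cc(OCC(N)=O)ccc3N2)c1=O` carries a carbamoylmethoxy chain on the shared core; in an in vitro ADME assay on microsomes from liver (Homo sapiens) for metabolic stability, tested at 5 uM (on this read-out lower numbers stand for a shorter-lived compound and higher numbers for a longer-lived compound), compound 1 gives 0.383 h. Compound 2 `CC(C)CCn1nc(-c2cccs2)c(O)c(C2=NS(=O)(=O)c3cc(OC(C)C(N)=O)ccc3N2)c1=O`, the methyl-branched analogue, gives 0.217 h in this assay, and the step is a 1.8-fold lower number from compound 1 to compound 2 (0.25 log units; within the scatter). Compound 3 `CC(C)CCn1nc(-c2cccs2)c(O)c(C2=NS(=O)(=O)c3cc(OCC(=O)NO)ccc3N2)c1=O` carries the hydroxamic acid. In this assay compound 3 reaches only a limit of the assay, reported as > 1 h; this is the limit of > 1 h in this assay, at which 1 of the 3 values shown sits. So compound 3 stands at the upper edge of the three without a number of its own. The steps into it are an at least 2.6-fold higher number from compound 1 to compound 3 (0.41 log units; beyond the scatter) and an at least 4.6-fold higher number from compound 2 to compound 3 (0.66 log units; beyond the scatter).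

Compound 4 `CC(C)CCn1nc(-c2cccs2)c(O)c(C2=NS(=O)(=O)c3cc(CCC(N)=O)ccc3N2)c1=O` differs from compound 3 as follows: 2-carbamoylethyl in place of (hydroxycarbamoyl)methoxy on an aromatic carbon. Within the data shown here, no measured step covers this exact exchange. The closest guide is the reverse of an at least 2.6-fold higher number from compound 1 to compound 3 (0.41 log units; beyond the scatter), since compound 4 returns to a primary amide with hydrogen on the amide nitrogen; that points back toward the region of compound 1. The exchange of the ether oxygen for a chain carbon is not covered by any measured pair. On this basis a step down from the limit is expected in this assay. Compound 4 is estimated at 0.5 h, with a range of 0.2 h to 1.2 h. The step this estimate implies is expected to be an at least 2.0-fold lower number from compound 3 to compound 4 (0.30 log units; that floor lies within the scatter).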

Compound 4, half-life: > 1 h
Compound 4 ended at the assay's limit (the forecaster's own chance of this, stated with the estimate: 15%); middle value at least 2.0-fold (0.30 log units) from the limit.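

In this assay compound 4 is recorded only as a limit of the assay, as compound 3 is, so the step between them cannot be read, and the upper edge of the series now holds both: the limit of > 1 h in this assay, at which 2 of the 4 values shown sit.

Exchanging carbamoylmethoxy for 2-carbamoylethyl on the aromatic carbon gives an at least 2.6-fold higher number from compound 1 to compound 4 (0.41 log units; beyond the scatter), and exchanging 1-carbamoylethoxy for the same chain gives an at least 4.6-fold higher number from compound 2 to compound 4 (0.66 log units; beyond the scatter). Among the earlier compounds only the hydroxamic acid of compound 3 reached the limit, whereas compound 4 shows that a primary amide can reach it at this position on a carbon-linked chain, so the hydroxy on the amide nitrogen is not needed for this result.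

On these data alone, with both compounds at the limit, the order of compound 3 and compound 4 and the distance of either beyond the limit stay unknown in this assay. Also open, as far as these compounds go, is whether the result holds for a longer chain, for a methyl branch on the 2-carbamoylethyl chain, or for a carboxylic acid or an amine in place of the primary amide.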